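Side-chain branching: from compound 2 to compound 3

The source may report more compounds than this note shows. Statements on the series, on what has been measured and on what is new or still open speak of the compounds shown alone.

Measured so far:
- compound 1, `CC(=O)c1ccc(NC(=O)CN(C(=O)c2ccccc2)S(=O)(=O)c2ccc(C)cc2)cc1`: in a functional assay for inhibition, read by spectrophotometry, with a stated time of 20 min, tested at 3 mg/mL (on this read-out higher numbers stand for a stronger effect at the one concentration tested and lower numbers for a weaker effect), compound 1 gives 18.2%
- compound 2, `CC(=O)c1ccc(NC(=O)C(CC(C)C)N(C(=O)c2ccccc2)S(=O)(=O)c2ccc(C)cc2)cc1`: in this assay compound 2 gives 63.1%

Within the data shown here, compound 2 holds the highest of the two numbers; the only other point is compound 1, and the single step between them, a number 44.9 percentage points higher from compound 1 to compound 2 (beyond the scatter), is large and well beyond the scatter. It comes from isobutyl in place of hydrogen on a saturated chain carbon bound to an amide-type nitrogen and a carbonyl carbon.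

Compound 3, `CCC(C)C(C(=O)Nc1ccc(C(C)=O)cc1)N(C(=O)c1ccccc1)S(=O)(=O)c1ccc(C)cc1`, differs from compound 2 by sec-butyl in place of isobutyl on a saturated chain carbon bound to an amide-type nitrogen and a carbonyl carbon. Among the measured compounds shown here, the two have the same atoms, joined differently, so the step bearing on it is only the one above, which shows that filling this position with isobutyl raises the read-out strongly. For the measured compounds named here, no measured pair shows what rearranging the branch does; the sec-butyl group keeps the chain and the place, so no step beyond the scatter is expected in this assay, with a slight lowering allowed for.

Compound 3 is therefore estimated at 57% in this assay, within 38% to 74%, an expected step of a number 6.1 percentage points lower from compound 2 to compound 3 (within the scatter).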

Compound 3, a percentage reported as inhibition, at one concentration (the size of the read-out at that concentration, not a potency): 33.4%
For compound 3 the middle estimate is 23.6 percentage points above the measured one; measured number outside the range, below it.
By their numbers in this assay, from the lowest: compound 1; then compound 3; then compound 2.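

At this saturated chain carbon, the arrangement of the branch counts as well as its presence: with the same atoms joined differently, sec-butyl in place of isobutyl gives a number 29.7 percentage points lower from compound 2 to compound 3 (beyond the scatter) in this assay. The position therefore does not respond to filling alone, and the large gain seen with isobutyl cannot be carried over to any group of the same size. Sec-butyl still improves on hydrogen, with a number 15.2 percentage points higher from compound 1 to compound 3 (beyond the scatter), so the three compounds rank hydrogen, then sec-butyl, then isobutyl, each separated from the next by more than the scatter. Nothing available accounts for the difference between the two branched groups.

With only hydrogen, isobutyl and sec-butyl shown at this carbon, it remains open whether the read-out follows the place of the branch or simply the shape of the chain; a straight n-butyl chain, a tert-butyl group or a benzyl group would help separate these. Also open, from the compounds shown here alone, is whether this order would hold at other concentrations, as each number here is the size of the effect at a single concentration and not a potency.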